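Swapping the aryl group on the cyclohexane of compound 3

The source may hold more compounds than are shown below. What is called first, only, known or untested is meant among the compounds shown, and "the series" means these compounds.

Of the compounds shown here, three have been tested in an in vitro functional assay on 1321-N1 cells for antagonist activity at P2X purinoceptor 7 (Homo sapiens), read by FLIPR and calcium flux; a higher number here means a weaker inhibitor, a lower number a stronger inhibitor. Compound 1 `Cc1ccccc1NNC(=O)CCC(C)C` gives 148 nM, and compound 2 `Cc1ccccc1NNC(=O)CC1CCCCC1` gives 38.9 nM. For the measured compounds named here, the one step between them, cyclohexyl in place of isobutyl on a saturated chain carbon bound to a carbonyl carbon, is a 3.8-fold lower number from compound 1 to compound 2 (0.58 log units; beyond the scatter). Compound 3 `COc1ccc(C2(C(=O)NNc3cccc4ncccc34)CCCCC2)cc1` gives 52.5 nM in this assay; its number sits close to that of compound 2, within the usual scatter, while it is lower than the number of compound 1.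

Compound 4 `O=C(NNc1cccc2ncccc12)C1(c2cccc(F)c2)CCCCC1` differs from compound 3 in a single place: 3-fluorophenyl in place of 4-methoxyphenyl on a saturated ring carbon. Going by the values given here, the only measured step concerns the group on the carbon next to the carbonyl, not the aryl group on the saturated ring, so no measured step bears directly on this change. Without such a precedent, the expectation in this assay is a step of no particular direction that stays within the usual scatter, with the range widened to allow for either outcome. The estimated step from compound 3 to compound 4 is a 1.1-fold higher number from compound 3 to compound 4 (0.06 log units; within the scatter). Compound 4 is therefore expected to give about 60 nM, with a likely range from 25 nM to 150 nM.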

Compound 4, half-maximal inhibitory concentration: 141 nM
For compound 4 the middle estimate is 2.4-fold (0.37 log units) below the measured one; the range from low to high includes it.
By their numbers in this assay, from the lowest: compounds 2 and 3 (each within the scatter of the next); then compounds 4 and 1 (each within the scatter of the next).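

In this assay, the aryl group on the saturated ring carbon turns out to matter: 3-fluorophenyl in place of 4-methoxyphenyl gives a 2.7-fold higher number from compound 3 to compound 4 (0.43 log units; beyond the scatter). For the compounds shown here, the earlier step concerned only the group on a chain carbon, so this is the first sign that the number responds to a change at this position, and the response here is towards a weaker inhibitor. As the two names show, however, the swap changes both the substituent on the phenyl ring and the place it occupies, and no measurement shown here explains the shift or separates these two changes.

On these data alone, it remains open whether 4-fluorophenyl or 3-methoxyphenyl on the same saturated ring carbon would give a number closer to that of compound 3 or to that of compound 4, a comparison that would help separate the choice of substituent from its place on the ring. Plain phenyl at this position is also an open case, as it would show whether the methoxy group, the fluorine or neither accounts for the difference between the two compounds.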